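The source may hold more compounds than are shown below. What is called first, only, known or untested is meant among the compounds shown, and "the series" means these compounds.

Working notes on the hydroxylated carboxamide series.

Three compounds have numbers in an assay on HL-60 cells for inhibition of E-selectin (Homo sapiens), tested at 50 mM; a lower number here means less inhibition, a higher number more inhibition at the concentration tested (going by the name of the read-out). Compound 1 `O=C(O)CCCNC(=O)[C@]1(O)C[C@@H](O)[C@@H](O)[C@H](O)C1` gives 40%. Compound 2 `O=C(O)CC[C@H](NC(=O)[C@]1(O)C[C@@H](O)[C@@H](O)[C@H](O)C1)C(=O)O` gives 43%. Compound 3 `C[C@H](NC(=O)[C@]1(O)C[C@@H](O)[C@@H](O)[C@H](O)C1)C(=O)O` gives 30%, the lowest of the three numbers; its nearest neighbour is compound 1, its furthest compound 2. The step of a number 3 percentage points higher from compound 1 to compound 2 (within the scatter) stays within the scatter, as does the step of a number 10 percentage points lower from compound 1 to compound 3 (within the scatter), while the step of a number 13 percentage points lower from compound 2 to compound 3 (beyond the scatter) lies beyond it and counts as modest.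

Compound 4 `O=C(O)[C@H](CO)NC(=O)[C@]1(O)C[C@@H](O)[C@@H](O)[C@H](O)C1` is not yet measured. Its difference from compound 3 is hydroxy in place of hydrogen on a saturated chain carbon, two bonds along the chain from an amide-type nitrogen and a carbonyl carbon. Going by the values given here, two measured steps bear on this. Among the compounds with values here, the step of a number 13 percentage points lower from compound 2 to compound 3 (beyond the scatter) removed a carboxymethyl at the same place and was the one change beyond the scatter; the step of a number 3 percentage points higher from compound 1 to compound 2 (within the scatter) added a carboxy on a saturated chain carbon bound to the amide-type nitrogen and stayed within the scatter. A hydroxy entering at that place is a smaller addition than the carboxymethyl of compound 2, so any rise in this assay is expected to stay small. The expected step is a number 6 percentage points higher from compound 3 to compound 4 (within the scatter), inside the scatter. Compound 4 is therefore estimated at 36%, with a range from 22% to 50%.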

Compound 4, a percentage reported as inhibition, at one concentration (the size of the read-out at that concentration, not a potency): 46%
For compound 4 the middle estimate is 10 percentage points below the measured one, and the stated range covers the measured number.
By their numbers in this assay, from the lowest: compounds 3, 1, 2 and 4 (each within the scatter of the next, the first and the last beyond it).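

Hydroxy in place of hydrogen on a saturated chain carbon, two bonds along the chain from an amide-type nitrogen and a carbonyl carbon, gives in this assay a number 16 percentage points higher from compound 3 to compound 4 (beyond the scatter), so a single added oxygen at this place already moves the number, a change seen before only with the larger carboxymethyl. Carboxymethyl is also not required for a number of this size, since exchanging it for hydroxy gives a number 3 percentage points higher from compound 2 to compound 4 (within the scatter), and the exchange of 3-carboxypropyl for 1-carboxy-2-hydroxyethyl on the amide-type nitrogen gives a number 6 percentage points higher from compound 1 to compound 4 (within the scatter). No supporting data accompany these numbers to explain the rise from hydrogen to hydroxy.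

The compounds shown leave open whether the free hydroxy is what matters at this place, which a methoxymethyl, an aminomethyl or a longer 2-hydroxyethyl group on the same carbon would test. They also leave open how much the carboxylic acid on that carbon contributes alongside the hydroxy, which a primary amide in its place would address, and whether the opposite configuration at that carbon gives a similar number.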